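Swapping bromine for chlorine on a thiazolylidene hydrazide

The source may report more compounds than this note shows. Statements on the series, on what has been measured and on what is new or still open speak of the compounds shown alone.

Of the compounds shown here, two have been measured in a functional assay on C6 cells (Rattus norvegicus) for cytotoxicity, read by MTT assay, with a stated time of 24 h, tested at 100 ug/mL; a lower number here means a stronger effect, a higher number a weaker effect of the compound at the concentration tested. Compound 1, `O=C(CSc1nnnn1-c1ccccc1)N/N=c1/scc(-c2ccc(Cl)cc2)n1-c1ccccc1`, gives 54.3% in this assay. Compound 2, `O=C(CSc1ncccn1)N/N=c1/scc(-c2ccc(Br)cc2)n1-c1ccccc1`, gives 67.6% in this assay, the higher of the two numbers and therefore the weaker effect; its gap to compound 1 lies beyond the usual scatter. The two also differ in more than one place, so no single change can be tied to that gap.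

Compound 3, `O=C(CSc1ncccn1)N/N=c1/scc(-c2ccc(Cl)cc2)n1-c1ccccc1`, is yet to be measured in this assay. It differs from compound 2 in one place only: chloro in place of bromo on an aromatic carbon. Compound 1 also carries a chloro group, but its other differences from compound 2 leave the effect of this single swap unknown. An exchange of one halogen for another of this kind is expected to move this assay little, so for compound 3 the step is expected to be small, within the scatter or close to it, and with no clear direction: a number 4.6 percentage points lower from compound 2 to compound 3 (within the scatter). The estimate for compound 3 in this assay is therefore 63%, with a range from 48% to 78%.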

Compound 3, a percentage reported as activity, at one concentration (the size of the read-out at that concentration, not a potency): 45.5%
The estimate for compound 3 lay 17.5 percentage points above the measured number, outside the stated range (below it).
By their numbers in this assay, from the lowest: compounds 3 and 1 (each within the scatter of the next); then compound 2.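

For the compounds shown here, at this position the identity of the halogen turns out to matter: in this assay, chloro in place of bromo on an aromatic carbon gives a number 22.1 percentage points lower from compound 2 to compound 3 (beyond the scatter) and so a stronger effect at the concentration tested, which is the first clean reading of this one change, since the earlier pair differed in more than one place. With the 4-chlorophenyl group kept, pyrimidin-2-yl in place of 1-phenyl-1H-tetrazol-5-yl on a sulfur gives a number 8.8 percentage points lower from compound 1 to compound 3 (within the scatter) and so the two groups on the sulfur cannot be told apart in this read-out, even though they differ considerably in size. No independent measurement bears on why exchanging one halogen for another shifts the number this much, so the step stands as an observation without an explanation.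

Going by these compounds, whether the same halogen step would appear with the 1-phenyl-1H-tetrazol-5-yl group on the sulfur remains open, as a single pair cannot show how general it is. Also open, on these data alone, is how fluoro, methyl, methoxy or an amine on that same aromatic carbon would compare with chloro and bromo.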